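The compounds below may be only part of what the source reports. "The series", "measured", "known", "first", "only" and "open" are said of these compounds alone.

Measured so far in a functional assay on A-431 cells (Homo sapiens) for antiproliferative activity, read by MTT assay, with a stated time of 72 h; on this read-out lower numbers stand for stronger inhibition and higher numbers for weaker inhibition:
- compound 1 `COc1ccc(Nc2cc(NC(=O)c3ccccc3)ncn2)cc1`: 9460 nM
- compound 2 `CCOC(=O)CCCC(=O)Nc1cc(Nc2cccc(Cl)c2)ncn1`: 490 nM
- compound 3 `COc1ccc(OC)c(Nc2cc(Nc3ccc(F)cc3)ncn2)c1`: > 30000 nM

Compound 3 stands at > 30000 nM, which is a limit of the assay and not a number. Within the data shown here, it is the only one of the three values that sits at a limit: the limit of > 30000 nM in this assay, at which 1 of the 3 values shown sits.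

Compound 4 `COc1cccc(Nc2cc(Nc3cc(OC)ccc3OC)ncn2)c1` carries 3-methoxyphenyl in place of 4-fluorophenyl on a nitrogen on an aromatic ring, and the rest of compound 3 is kept: 3-methoxyphenyl in place of 4-fluorophenyl on a nitrogen on an aromatic ring.

Among the measured compounds shown here, no measured pair shows this exchange. Compound 1 and compound 2 differ from compound 3 in more than one place, so neither gives a step to carry over. The expectation therefore rests on compound 3 alone, whose > 30000 nM is a limit.

In this assay no step beyond the scatter is expected in either direction, and the estimated step is a number no higher from compound 3 to compound 4 (the limit leaves the size open). A result reported only as a limit is also quite likely.

For compound 4 the estimated value is 30000 nM, with an expected range of 10000 nM to 70000 nM.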

Compound 4, half-maximal inhibitory concentration: 740 nM
Compound 4: the middle estimate sits 41-fold (1.61 log units) above what was measured, outside the stated range (below it).
By their numbers in this assay, from the lowest: compounds 2 and 4 (each within the scatter of the next); then compound 1. At a limit, above all of these: compound 3.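

In this assay, among these compounds, this is the first single-place change, and it shows that the group on this nitrogen on an aromatic ring can strongly shift the read-out. With the rest of compound 3 kept, 3-methoxyphenyl in place of 4-fluorophenyl gives an at least 40-fold lower number from compound 3 to compound 4 (1.60 log units; beyond the scatter). The value for compound 3 is a limit and not a number, so the true size of this step stays unknown: the limit of > 30000 nM in this assay, at which 1 of the 4 values shown sits.

The compounds shown do not separate the contribution of the methoxy oxygen from that of the rest of the entering group. Going by these compounds, how a plain phenyl or a 3-aminophenyl would read on this nitrogen, with the rest of compound 3 kept, remains open.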